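A few compounds are considered here, and "the series" means these few. Any claim that something is new, unique, unknown or untested is made for them only; others in the source may bear on it.

Series notes, cytotoxicity on hamster kidney cells.

Compound 1 `COc1ccc(-c2nc3cc(C(C)=O)ccc3[nH]2)c(OC)c1` carries an acetyl on the shared core; in an ADME assay on BHK-21 cells (Mesocricetus auratus) for cytotoxicity, read by MTT assay (a lower number here means that less compound is tolerated, a higher number that more compound is tolerated), compound 1 gives 50000 nM. Compound 2 `COc1ccc(-c2nc3cc(/C(C)=N/NC(N)=O)ccc3[nH]2)c(OC)c1` is the matched partner. For compound 2 the read-out in this assay is a limit, >= 100000 nM, not a number. The change between them is a group of 7 heavy atoms (3 carbon, 3 nitrogen, 1 oxygen; no ring) in place of a group of 3 heavy atoms (2 carbon, 1 oxygen; no ring), on an aromatic carbon, and it gives an at least 2.0-fold higher number from compound 1 to compound 2 (0.30 log units; that floor lies within the scatter). The size of that step is uncertain, since it sits against (the limit of >= 100000 nM in this assay, at which 1 of the 3 values shown sits).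

Compound 3 `CC(=O)c1ccc2c(c1)nc(-c1ccccc1)n2C1CCCCC1` has a different core; how it differs from compound 1 is not broken down here. In this assay compound 3 gives 100000 nM. The values of compound 1 and compound 3 lie within the usual scatter of one another, so no order between them is read.

Compound 4 `C/C(=N\NC(N)=O)c1ccc2c(c1)nc(-c1ccccc1)n2C1CCCCC1` is not yet measured. Within the data shown here, it differs from compound 3 by a group of 7 heavy atoms (3 carbon, 3 nitrogen, 1 oxygen; no ring) in place of a group of 3 heavy atoms (2 carbon, 1 oxygen; no ring), on an aromatic carbon, the same change as the one from compound 1 to compound 2, on the same place of the core.

The step is expected to be no change at the digits printed from compound 3 to compound 4 (within the scatter), resting on the earlier step of an at least 2.0-fold higher number from compound 1 to compound 2 (0.30 log units; that floor lies within the scatter), which pointed toward better tolerance without a firm size. Given the value of compound 3, 100000 nM, the estimate for compound 4 is 100000 nM, with the range 50000 nM to 200000 nM. There is also a real chance that the read-out for compound 4 is reported only as a limit.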

Compound 4, half-maximal cytotoxic concentration: > 100000 nM
Compound 4 was reported as a limit; the forecaster's own chance of this, stated with the estimate: 70%; the middle value lies on the limit itself.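

In this assay compound 4 gives > 100000 nM, a limit of the assay and not a number. Replacing the acetyl on this second core gives a number no lower from compound 3 to compound 4 (the limit leaves the size open), and set beside the same change on the core of compound 1, the comparison reads: the same change on two cores in this assay, an at least 2.0-fold higher number (0.30 log units; that floor lies within the scatter) from compound 1 to compound 2 and a number no lower (the limit leaves the size open) from compound 3 to compound 4; the limit leaves it open whether they differ. The change therefore gives no lower number on either of the two cores shown, but this does not show that it raises the number on either core, nor that its size carries over from one core to the other.

From the compounds shown here alone, how far the tolerated concentrations of the two products lie past their limits remains open, and with it any ranking of the two cores after the change. Also open, going by these compounds, is what other replacements for the acetyl on these cores, such as an amine, a carboxylic acid or a longer chain, would give, and whether the result holds on a third core.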